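This account rests on a few compounds, and the source may have more. Where it says the series, first, only, none or still open, it means among the compounds named here.

Measured so far:
- compound 1 `COc1ccc(-c2nc(SCC(=O)c3sc(-c4ccccc4)nc3C)nc(N)c2C#N)cc1` gives 14000 nM
- compound 2 `COc1ccc(-c2nc(SCC(=O)c3sc(-c4ccccc4)nc3C)[nH]c(=O)c2C#N)cc1` gives 48400 nM
- compound 3 `Cc1nc(-c2ccccc2)sc1C(=O)CSc1nc(-c2ccccc2)c(C#N)c(=O)[nH]1` gives 56600 nM

All three values come from a functional assay on U-87MG ATCC cells for antiproliferative activity against U-87 MG (Homo sapiens), read by MTT assay, with a stated time of 48 h; on this read-out lower numbers stand for stronger inhibition and higher numbers for weaker inhibition. Compound 1 has the lowest number of the three, and its gap to each of the other two lies beyond the usual scatter of repeated measurements.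

Compound 4 `Cc1nc(-c2ccccc2)sc1C(=O)CSc1nc(N)c(C#N)c(-c2ccccc2)n1` has not been measured yet. It differs from compound 1 by a single change, hydrogen in place of methoxy on an aromatic carbon, para to a large group: hydrogen in place of methoxy on an aromatic carbon.

Among the measured compounds shown here, one measured step bears on this, because the same swap links compounds 2 and 3: a 1.2-fold higher number from compound 2 to compound 3 (0.07 log units; within the scatter). For the measured compounds named here, that is only one example, and its core differs from that of compound 1, so it is a limited guide.

No shift beyond the scatter is therefore expected, and the estimated step is a 1.2-fold higher number from compound 1 to compound 4 (0.07 log units; within the scatter). In this assay, the expected value for compound 4 is 16500 nM, with an estimated range from 8000 nM to 34000 nM.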

Compound 4, half-maximal inhibitory concentration: 29000 nM
Beside the measured number, compound 4's estimate is 1.8-fold (0.24 log units) below it, within the range that was stated.
By their numbers in this assay, from the lowest: compound 1; then compounds 4, 2 and 3 (each within the scatter of the next).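

In this assay, the change from 4-methoxyphenyl to phenyl now gives a step that clears the usual scatter: a 2.1-fold higher number from compound 1 to compound 4 (0.32 log units; beyond the scatter). The methoxy group therefore makes a modest measurable difference on the core of compound 1, which the earlier pair, with its step within the scatter, did not show. This does not prove that the two cores respond differently to the change, since the gap between the two steps is itself within the scatter: the same change on two cores in this assay, a 1.2-fold higher number (0.07 log units; within the scatter) from compound 2 to compound 3 and a 2.1-fold higher number (0.32 log units; beyond the scatter) from compound 1 to compound 4, 1.8-fold (0.25 log units) apart, within the scatter of two such steps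

Among the compounds shown, this position carries only methoxy or hydrogen, so it remains open how a hydroxyl group, a chlorine atom or a longer ethoxy chain would read there. On these data alone, with just two pairs, the size of this change on other cores also remains open.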